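The source may hold more compounds than are shown below. What is called first, only, known or untested is meant among the compounds shown, and "the series" means these compounds.

Of the compounds shown here, two built on the same shared core have been measured in a functional assay on A375P cells (Homo sapiens) for antiproliferative activity, read by MTT assay, with a stated time of 24 h; on this read-out lower numbers stand for stronger inhibition and higher numbers for weaker inhibition. Compound 1 `O=C(Nc1ccc(-n2ccc3c(NC(=O)c4ccccc4)ncnc32)cc1)c1ccc(Cl)c(Cl)c1` gives 2000 nM, and compound 2 `O=C(Nc1ccc(-n2ccc3c(NC(=O)c4ccccc4)ncnc32)cc1)Nc1cccc(C(F)(F)F)c1` gives 9500 nM. For the measured compounds named here, compound 2 therefore stands at the higher of the two numbers, and the only measured step, a 4.8-fold higher number from compound 1 to compound 2 (0.68 log units; beyond the scatter), separates it from compound 1. That step changed two things at once: the group on the carbonyl carbon and the link through which it is attached, so it speaks only indirectly to the change considered here.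

Compound 3 `O=C(Nc1ccc(-n2ccc3c(NC(=O)c4ccccc4)ncnc32)cc1)Nc1cccc(Cl)c1Cl` differs from compound 2 in one place: 2,3-dichlorophenyl in place of 3-(trifluoromethyl)phenyl on an amide-type nitrogen. Here the amide-type nitrogen and its carbonyl carbon stay in place, and only the aromatic ring beyond them is exchanged. The measured step hints that a dichlorophenyl ring sat on the lower side of the numbers, but since the link was also different in that comparison, the expectation remains cautious. The step from compound 2 to compound 3 is estimated at a 1.9-fold lower number from compound 2 to compound 3 (0.28 log units; within the scatter), a lowering of the number. On this basis compound 3 is expected to give 5000 nM, within a range from 1500 nM to 16000 nM.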

Compound 3, half-maximal inhibitory concentration: 4100 nM
For compound 3 the middle estimate is 1.2-fold (0.09 log units) above the measured one; low and high end bracket the measured number.
By their numbers in this assay, from the lowest: compound 1; then compound 3; then compound 2.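

In this assay, the exchange of 3-(trifluoromethyl)phenyl for 2,3-dichlorophenyl gives a 2.3-fold lower number from compound 2 to compound 3 (0.36 log units; beyond the scatter). With the amide-type nitrogen and its carbonyl carbon held in place, this shows that the aromatic ring alone can shift the number, although only modestly. The other new step, a 2.1-fold higher number from compound 1 to compound 3 (0.31 log units; beyond the scatter), shows that a dichlorophenyl ring does not by itself bring the number down to that of compound 1, but this step changes both the link and the chlorine pattern, and no measurement available here explains either step.

The compounds shown leave open how much of that last step belongs to the added amino link and how much to the move from 3,4-dichlorophenyl to 2,3-dichlorophenyl, a question that (3,4-dichlorophenyl)amino on the same carbonyl carbon would separate. They also leave open how this position responds to a plain phenyl ring or to rings carrying a methoxy group or an amine, none of which are among the compounds shown.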